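The compounds below may be only part of what the source reports. "The series", "measured", "known", "first", "only" and "open" are said of these compounds alone.

Measured so far:
compound 1 `O=C(N/N=C/c1ccc(CSc2nc3ccccc3o2)cc1)c1ccncc1` — 66.6%
compound 2 `O=C(N/N=C/c1ccc(CSc2nc3ccccc3s2)cc1)c1ccncc1` — 34%

In an ADME assay on microsomes from liver (Homo sapiens) for metabolic stability, read by LC-MS, with a stated time of 60 min (on this read-out lower numbers stand for a less stable compound and higher numbers for a more stable compound), compound 1 gives 66.6%, and compound 2 gives 34%. The single measured step, a number 32.6 percentage points lower from compound 1 to compound 2 (beyond the scatter), leaves compound 2 with the lowest number of the two shown, with compound 1 as the nearest neighbour at a distance beyond the scatter.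

Compound 3 `O=C(N/N=C/c1ccc(CSc2nc3ccccc3[nH]2)cc1)c1ccncc1` is the next member. It differs from compound 2 by 1H-benzimidazol-2-yl in place of 1,3-benzothiazol-2-yl on a sulfur. For the measured compounds named here, the only step that bears on this position, a number 32.6 percentage points lower from compound 1 to compound 2 (beyond the scatter), concerns a different exchange at the same sulfur and shows that this position can move this assay by a large amount; it does not tell the direction for the present change. A step of size a number 16 percentage points higher from compound 2 to compound 3 (beyond the scatter) is therefore expected, with a wide range in either direction. Compound 3 is estimated at 50%, within 25% to 78%.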

Compound 3, percent of the compound remaining: 44.6%
Estimate against measurement, compound 3: 5.4 percentage points above; the range from low to high includes it.
By their numbers in this assay, from the lowest: compound 2; then compound 3; then compound 1.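

In this assay, this exchange on the sulfur now has a measured direction, with 1H-benzimidazol-2-yl replacing 1,3-benzothiazol-2-yl giving a number 10.6 percentage points higher from compound 2 to compound 3 (beyond the scatter) as a modest change. Replacing 1,3-benzoxazol-2-yl with 1H-benzimidazol-2-yl gives a number 22 percentage points lower from compound 1 to compound 3 (beyond the scatter), so the new group falls between the other two and the three groups form an order with every gap beyond the scatter. No measurement at hand explains this order.

Open, from the compounds shown here alone, is where a 1-methylbenzimidazol-2-yl group, with a methyl on the ring nitrogen in place of its hydrogen, would fall in this order. Also open, going by these compounds, are how a chloro group on the six-membered ring would move the number and whether the order of the three groups would hold on a different core.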